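Notes on the aryl swap from compound 2 to compound 3

The source may report more compounds than this note shows. Statements on the series, on what has been measured and on what is new or still open speak of the compounds shown alone.

Compound 2 `COc1cc(OCc2csc(-c3ccc(C(N)=O)cc3)n2)c2cc(-c3cn4nc(OC)sc4n3)oc2c1` gives 0.3 nM in a functional assay on HEK293 cells for antagonist activity at proteinase-activated receptor 4 (Homo sapiens), read by FLIPR and calcium flux, with a stated time of 30 min (a higher number here means a weaker inhibitor, a lower number a stronger inhibitor), the lowest of the two numbers recorded so far. Within the data shown here, its nearest neighbour is compound 1 `COc1cc(OCc2csc(-c3ccc(C(F)(F)F)cc3)n2)c2cc(-c3cn4nc(OC)sc4n3)oc2c1`, which in this assay gives 1.3 nM; the step of a 4.3-fold lower number from compound 1 to compound 2 (0.64 log units; beyond the scatter) is the only measured step and corresponds to carbamoyl in place of trifluoromethyl on an aromatic carbon.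

Compound 3 `COc1cc(OCc2csc(-c3ccc(OC)nc3)n2)c2cc(-c3cn4nc(OC)sc4n3)oc2c1` differs from compound 2 by 6-methoxypyridin-3-yl in place of 4-carbamoylphenyl on an aromatic carbon, so the carbamoyl group that accompanied the lower number in compound 2 is no longer present, and the ring that replaces it carries a methoxy group and a ring nitrogen instead. Among the measured compounds shown here, no measured step covers this exact exchange; the step from compound 1 to compound 2 bears on it only in that removing the carbamoyl may undo part of what that step gained. For compound 3 a modest rise in this assay is therefore expected, roughly a 3.3-fold higher number from compound 2 to compound 3 (0.52 log units; beyond the scatter), back toward the number of compound 1. The estimated value for compound 3 is 1 nM, with a plausible range from 0.3 nM to 4 nM.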

Compound 3, half-maximal inhibitory concentration: 0.8 nM
Beside the measured number, compound 3's estimate is 1.3-fold (0.10 log units) above it; measured number inside the range.
By their numbers in this assay, from the lowest: compound 2; then compounds 3 and 1 (each within the scatter of the next).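

In this assay the exchange at this aromatic carbon of the five-membered ring gives a 2.7-fold higher number from compound 2 to compound 3 (0.43 log units; beyond the scatter) and so removes part of the advantage seen with 4-carbamoylphenyl, although 6-methoxypyridin-3-yl has no hydrogen-bond donor and the number remains below that of neither more than the printed steps show. The comparison with the trifluoromethyl-bearing aryl group gives a 1.6-fold lower number from compound 1 to compound 3 (0.21 log units; within the scatter) and thus does not separate 6-methoxypyridin-3-yl from 4-(trifluoromethyl)phenyl at this position, leaving compound 2 as the only one of the three set apart from both others by steps beyond the scatter. Nothing available on these compounds accounts for the differences.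

On these data alone, the exchange leading to compound 3 alters the ring and its substituent together, so the separate contributions of the ring nitrogen and the methoxy group remain open. Also open is whether a carboxylic acid, a nitrile or an aminomethyl group in place of the carbamoyl would keep the number of compound 2 0.3 nM in this assay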